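Working notes on the paw edema series: compound 3 to compound 4

The compounds below may be only part of what the source reports. "The series", "measured", "known", "first", "only" and "open" are said of these compounds alone.

Compound 3 `N#CC1=C(NCN2CCCCC2)N(c2ccccc2)C(=O)N2CCCCC(N3CCCC3)C12` gives 36.9% in a functional assay on the whole organism (strain albino) for inhibition, with Rattus norvegicus as the target, read by paw edema, with stated times of 1 h and 2 h, at a dose of 20 mmol/kg by the intraperitoneal route; on this read-out lower numbers stand for less inhibition and higher numbers for more inhibition at the one dose given (going by the name of the read-out). Of the three numbers shown it stands at the lower end, but compound 2 `COc1ccc(N/C=N/C2=C(C#N)C3C(N4CCCC4)CCCCN3C(=O)N2c2ccccc2)cc1` gives 37.2% and compound 1 `N#CC1=C(/N=C/Nc2ccc([N+](=O)[O-])cc2)N(c2ccccc2)C(=O)N2CCCCC(N3CCCC3)C12` gives 41.5%, and the steps of a number 0.3 percentage points lower from compound 2 to compound 3 (within the scatter) and a number 4.6 percentage points lower from compound 1 to compound 3 (within the scatter) are both within the scatter, so the three compounds cannot be ranked. The remaining step, a number 4.3 percentage points lower from compound 1 to compound 2 (within the scatter), is likewise within the scatter.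

Compound 4 `N#CC1=C(/N=C/c2ccccc2)N(c2ccccc2)C(=O)N2CCCCC(N3CCCC3)C12` differs from compound 3 in one place: a group of 8 heavy atoms (7 carbon, 1 nitrogen; one six-membered aromatic ring of carbon only) in place of a group of 8 heavy atoms (6 carbon, 2 nitrogen; one six-membered non-aromatic ring with 1 hetero atom), on a double-bonded ring carbon. The two measured steps that alter the group at this same position, a number 4.6 percentage points lower from compound 1 to compound 3 (within the scatter) and a number 0.3 percentage points lower from compound 2 to compound 3 (within the scatter), both stayed within the scatter even though the groups exchanged there differed considerably in size and composition. Among the compounds with values here, no measured step bears directly on an aromatic ring joined through a double bond at this position. The expected step of a number 1.1 percentage points higher from compound 3 to compound 4 (within the scatter) is therefore estimated to lie within the scatter. Compound 4 is expected to give 38%, with a range from 27% to 49%.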

Compound 4, a percentage reported as inhibition, in the whole organism at one dose (the size of the read-out at that dose, not a potency): 75.9%
Compound 4: middle estimate off by 37.9 percentage points, on the low side; the whole stated range lies below it.
By their numbers in this assay, from the lowest: compounds 3, 2 and 1 (each within the scatter of the next); then compound 4.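

In this assay the group on this double-bonded ring carbon proves to matter: the step of a number 39 percentage points higher from compound 3 to compound 4 (beyond the scatter) sets compound 4 apart, whereas every earlier step at this place stayed within the scatter. The comparison with the two aryl amino groups agrees, since both the step of a number 38.7 percentage points higher from compound 2 to compound 4 (beyond the scatter) and the step of a number 34.4 percentage points higher from compound 1 to compound 4 (beyond the scatter) come from phenyl replacing an arylamino group on the carbon with a double bond to nitrogen. Among these four compounds, only compound 4 stands apart, while (4-nitrophenyl)amino, (4-methoxyphenyl)amino and ((piperidin-1-yl)methyl)amino give no order among themselves.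

Nothing available explains the size of these steps.
As far as these compounds go, it also remains open whether a pyridine ring, a cyclohexyl group or a methoxy-bearing phenyl ring in the place of this phenyl would keep the higher number.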